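Working notes: bromo to trifluoromethoxy swap

The compounds below may be only part of what the source reports. "The series", "measured", "known", "first", "only" and "open" are said of these compounds alone.

Measured in a functional assay on RAW264.7 cells (Mus musculus) for inhibition, read by Griess assay, with stated times of 1 h and 24 h (a higher number here means a weaker inhibitor, a lower number a stronger inhibitor), so far:
- compound 1 `CCCCOc1ccc(C(O)C2OC(=O)c3c(OC)cc(OC)cc32)cc1` gives 1800 nM
- compound 2 `CCCCCCOc1ccc(C(O)C2OC(=O)c3c(OC)cc(OC)cc32)cc1` gives 5360 nM
- compound 3 `COc1cc(OC)c2c(c1)C(C(O)c1ccc(OCc3ccc(Br)cc3)cc1)OC2=O` gives 6530 nM

Compound 3 has the highest number of the three, level within the scatter with compound 2 and beyond it above compound 1. Compound 4 `COc1cc(OC)c2c(c1)C(C(O)c1ccc(OCc3ccc(OC(F)(F)F)cc3)cc1)OC2=O` differs from compound 3 by trifluoromethoxy in place of bromo on an aromatic carbon. Among the compounds with values here, no measured step covers this change. The nearest steps alter the chain on the oxygen: a 3.0-fold higher number from compound 1 to compound 2 (0.47 log units; beyond the scatter) and a 3.6-fold higher number from compound 1 to compound 3 (0.56 log units; beyond the scatter) were modest, while a 1.2-fold higher number from compound 2 to compound 3 (0.09 log units; within the scatter) stayed within the scatter. No step beyond the scatter is therefore expected in this assay. The expected change is a 1.2-fold lower number from compound 3 to compound 4 (0.07 log units; within the scatter) by this estimate. Compound 4 is estimated at 5500 nM, with an expected range of 2200 nM to 14000 nM overall.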

Compound 4, half-maximal inhibitory concentration: 8140 nM
Compound 4: the middle estimate sits 1.5-fold (0.17 log units) below what was measured; the range from low to high includes it.
By their numbers in this assay, from the lowest: compound 1; then compounds 2, 3 and 4 (each within the scatter of the next).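

In this assay, trifluoromethoxy in place of bromo on this aromatic carbon gives a 1.2-fold higher number from compound 3 to compound 4 (0.10 log units; within the scatter), so the first change made at this position leaves the number level. The 4-(trifluoromethoxy)phenyl group also stays level with pentyl, at a 1.5-fold higher number from compound 2 to compound 4 (0.18 log units; within the scatter), but not with propyl, at a 4.5-fold higher number from compound 1 to compound 4 (0.66 log units; beyond the scatter), leaving compound 1 alone below the other three. No available evidence bears on this result.

Going by these compounds, whether an amine or a carboxylic acid on this aromatic carbon would also leave the number level remains open. So does whether an ethyl chain on the oxygen would fall below compound 1.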